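Swapping an Aromatic Ester Tail for a Branched Alkyl Chain

The source may hold more compounds than are shown below. What is called first, only, known or untested is meant among the compounds shown, and "the series" means these compounds.

Compound 1 `C/C=C1/[C@H](O[C@@H]2O[C@H](COC(C)=O)[C@@H](OC(C)=O)[C@H](OC(C)=O)[C@H]2OC(C)=O)OC=C(C(=O)OC)[C@H]1CC(=O)OCCC`: 6600 nM
Compound 2 `C/C=C1/[C@H](O[C@@H]2O[C@H](CO)[C@@H](O)[C@H](O)[C@H]2O)OC=C(C(=O)OC)[C@H]1CC(=O)OCCc1ccc(O)cc1`: a limit, > 20000 nM
Compound 3 `C/C=C1/[C@H](O[C@@H]2O[C@H](COC(C)=O)[C@@H](OC(C)=O)[C@H](OC(C)=O)[C@H]2OC(C)=O)OC=C(C(=O)OC)[C@H]1CC(=O)OC`: a limit, > 15000 nM

All three were tested in a functional assay on SK-BR-3 cells (Homo sapiens) for antiproliferative activity, read by MTT assay, with a stated time of 72 h; a lower number here means a stronger inhibitor, a higher number a weaker inhibitor. Compound 1 gives 6600 nM. For compound 2 the assay reports only a limit, > 20000 nM. For compound 3 likewise only a limit is reported, > 15000 nM. Compound 2 therefore stands at a limit, and one other value here is also a limit. The unmeasured compound 4 `C/C=C1/[C@H](O[C@@H]2O[C@H](CO)[C@@H](O)[C@H](O)[C@H]2O)OC=C(C(=O)OC)[C@H]1CC(=O)OCCC(C)C` differs from compound 2 by isopropyl in place of 4-hydroxyphenyl on a saturated chain carbon, two bonds along the chain from an oxygen next to a carbonyl group. For the measured compounds named here, the only measured step concerns the ester chain: an at least 2.2-fold higher number from compound 1 to compound 3 (0.35 log units; beyond the scatter). Going by the values given here, no measured step covers exchanging an aromatic group for an alkyl one on the free-sugar core, so the expectation is loose. Compound 4 is expected to give 15000 nM (range 4000 nM to 60000 nM), which would mean an estimated at least 1.3-fold lower number from compound 2 to compound 4 (0.12 log units; that floor lies within the scatter).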

Compound 4, half-maximal inhibitory concentration: 9020 nM
For compound 4 the middle estimate is 1.7-fold (0.22 log units) above the measured one; low and high end bracket the measured number.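

On the free-sugar core, isopropyl in place of 4-hydroxyphenyl gives an at least 2.2-fold lower number from compound 2 to compound 4 (0.34 log units; beyond the scatter) in this assay. The earlier step changed the ester chain only on the core with acetate-capped sugar hydroxyls, so this step alone shows that the 4-hydroxyphenyl ring is not needed at this place for a measurable number on the free-sugar core. Compound 2 stands only at a limit, not at a true number: the limit of > 20000 nM in this assay, at which 1 of the 4 values shown sits.

The compounds shown do not separate the ring from its hydroxyl, which a plain phenyl group at this place would test. As far as these compounds go, whether a longer alkyl chain or a chain ending in an amine would lower the number further also stays open.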